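Swapping methoxy for fluoro: an estimate for compound 4

A few compounds are considered here, and "the series" means these few. Any claim that something is new, unique, unknown or untested is made for them only; others in the source may bear on it.

- compound 1 `O=C1OC[C@H](Cc2ccccc2)[C@H]1Cc1ccc(Cl)c(Cl)c1` gives 26000 nM
- compound 2 `O=C1OC[C@H](Cc2ccccc2F)[C@H]1Cc1ccc(Cl)c(Cl)c1` gives "not determined" (no result reported)
- compound 3 `COc1cccc(C[C@H]2COC(=O)[C@@H]2Cc2ccc(Cl)c(Cl)c2)c1` gives "not determined" (no result reported)

These three compounds share one core and were examined in a functional assay on HeLa cells (Homo sapiens) for cytotoxicity, read by WST assay, with a stated time of 48 h; a lower number here means that less compound is needed, a higher number that more compound is needed for the effect. Only compound 1 has a usable number (26000 nM), so it is the sole anchor here. Compound 3 has no place on the scale, since its entry ("not determined" (no result reported)) carries no result, and compound 2 is in the same position ("not determined" (no result reported)).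

The next compound, compound 4 `O=C1OC[C@H](Cc2cccc(F)c2)[C@H]1Cc1ccc(Cl)c(Cl)c1`, is built from compound 3 by one small change (fluoro in place of methoxy on an aromatic carbon). Fluoro takes the place of methoxy on an aromatic carbon, meta to a large group. Among the measured compounds shown here, no pair of compounds here has two numbers, so the data show no measured size for any structural step. With nothing pointing either way, the expectation is for no step beyond the usual scatter of this assay, with compound 4 landing in the same region as compound 1 (26000 nM). That expectation is loose, as it rests on a single value.

For compound 4 the estimated value is 26000 nM, with an expected range of 10000 nM to 65000 nM.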

Compound 4, half-maximal effective concentration: 20000 nM
For compound 4 the middle estimate is 1.3-fold (0.11 log units) above the measured one; low and high end bracket the measured number.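

In this assay, among the compounds shown here, the 3-fluorophenyl group of compound 4 gives the first measured step at this position, with fluoro in place of hydrogen on an aromatic carbon, meta to a large group: a 1.3-fold lower number from compound 1 to compound 4 (0.11 log units; within the scatter). On this evidence, that single replacement cannot be told apart from the unsubstituted ring of compound 1, so the two compounds sit together on the scale. The change from methoxy to fluoro itself cannot be read, since compound 3 has no result, and nothing available here bears on why compound 1 and compound 4 fall so close together.

On these data alone, whether an amine, a carboxylic acid or a longer chain such as propyl on this same aromatic carbon would move the number beyond the usual scatter remains open. Hydrogen and fluoro are the only two groups readable here, and one small swap on one ring says little about how the rest of the shared core responds to change.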